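Inverting One Stereocentre on a Vitamin D3 Receptor Agonist

The compounds below may be only part of what the source reports. "The series", "measured", "known", "first", "only" and "open" are said of these compounds alone.

Compound 1, `CCN(CC)CCNC(=O)c1cc(C(CC)(CC)c2ccc(C#CC(O)(CC)CC)c(C)c2)cn1CC`: in an assay on cells for agonist activity at vitamin D3 receptor (Homo sapiens), read by microscopy (a lower number here means that less compound is needed, a higher number that more compound is needed for the effect), compound 1 gives 6.98 nM.
Compound 2, `CCn1cc(C(CC)(CC)c2ccc(C#CC(O)(CC)CC)c(C)c2)cc1C(=O)N[C@H](C(=O)O)C(C)C`: in this assay compound 2 gives 12.7 nM.

Compound 2 has the higher of the two numbers, yet the step of a 1.8-fold higher number from compound 1 to compound 2 (0.26 log units; within the scatter) is within the scatter. Compound 3, `CCn1cc(C(CC)(CC)c2ccc(C#CC(O)(CC)CC)c(C)c2)cc1C(=O)N[C@@H](C(=O)O)C(C)C`, differs from compound 2 only in configuration: the two compounds have the same atoms and bonds and differ only in configuration as drawn: 1 of 1 stereo elements differ; a stereocentre at a saturated chain carbon is drawn S in compound 2 and R in compound 3. Among the measured compounds shown here, no measured step bears on such an inversion; the one known step concerns the amide substituent, not this centre. Compound 3 is therefore expected close to compound 2, with a wide range, as a 1.6-fold higher number from compound 2 to compound 3 (0.20 log units; within the scatter). Compound 3 is estimated at 20 nM, between 5 nM and 80 nM.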

Compound 3, half-maximal effective concentration: 68.3 nM
Compound 3: middle estimate off by 3.4-fold (0.53 log units), on the low side; measured number inside the range.
By their numbers in this assay, from the lowest: compounds 1 and 2 (each within the scatter of the next); then compound 3.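

Inverting this stereocentre from S to R gives a 5.4-fold higher number from compound 2 to compound 3 (0.73 log units; beyond the scatter), so the configuration at this carbon matters, although the amide substituent change from compound 1 to compound 2 stayed within the scatter. This shift can be assigned to the inversion alone, because no atom or bond changes: the fact that compounds 2 and 3 differ only in the configuration as drawn
With the R configuration, the same substituent change gives a 9.8-fold higher number from compound 1 to compound 3 (0.99 log units; beyond the scatter).

On these data alone, it remains open whether the S form keeps its lower number when this carbon carries a longer chain, or when a primary amide replaces the carboxylic acid.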